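This account rests on a few compounds, and the source may have more. Where it says the series, first, only, none or still open, it means among the compounds named here.

Measured compounds:
- compound 1, `O=S(=O)(c1ccc(F)c(Cl)c1)c1cnc2cc(F)ccc2c1-c1cccc(Cl)c1`, 0.66 mL/min
- compound 2, `O=S(=O)(c1ccc(F)c(Cl)c1)c1cnc2cc(F)ccc2c1-c1cccc(F)c1`, 0.25 mL/min
- compound 3, `COc1ccc(-c2c(S(=O)(=O)c3ccc(F)c(Cl)c3)cnc3cc(F)ccc23)cc1`, 1.08 mL/min

In an ADME assay on microsomes from liver (Homo sapiens) for metabolic stability, tested at 2.5 uM (on this read-out lower numbers stand for slow clearance and higher numbers for fast clearance), compound 1 gives 0.66 mL/min, the second highest of the three numbers. Its nearest neighbour is compound 3, and the step of a 1.6-fold higher number from compound 1 to compound 3 (0.21 log units; within the scatter) lies within the scatter. Its furthest neighbour is compound 2, and the step of a 2.6-fold lower number from compound 1 to compound 2 (0.42 log units; beyond the scatter) is modest. The third measured step, a 4.3-fold higher number from compound 2 to compound 3 (0.64 log units; beyond the scatter), is also modest. Every one of these steps changes the aryl group on the aromatic carbon of the shared core.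

Compound 4, `COc1cccc(S(=O)(=O)c2cnc3cc(F)ccc3c2-c2cccc(Cl)c2)c1`, differs from compound 1 elsewhere: 3-methoxyphenyl in place of 3-chloro-4-fluorophenyl on a sulfonyl sulfur. Among the compounds with values here, no measured step alters the group on the sulfonyl sulfur, so none of the three steps bears directly on this change. With the measured steps at this position spanning only modest sizes, and no guide for the sulfonyl position, the step of a 1.2-fold higher number from compound 1 to compound 4 (0.08 log units; within the scatter) is expected to stay within the scatter, with no clear direction. Compound 4 is therefore estimated at 0.8 mL/min in this assay, within a range of 0.3 mL/min to 2 mL/min.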

Compound 4, intrinsic clearance in a liver preparation (reported as CLH), per the amount of preparation that the assay uses: 2.97 mL/min
Compound 4: the middle estimate sits 3.7-fold (0.57 log units) below what was measured, outside the stated range (above it).
By their numbers in this assay, from the lowest: compound 2; then compounds 1 and 3 (each within the scatter of the next); then compound 4.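

In this assay, the group on the sulfonyl sulfur turns out to matter: 3-methoxyphenyl in place of 3-chloro-4-fluorophenyl gives a 4.5-fold higher number from compound 1 to compound 4 (0.65 log units; beyond the scatter). Within the data shown here, the earlier steps all changed the aryl group on the aromatic carbon of the shared core, so this is the first sign that the sulfonyl position can also move the number beyond the scatter. The two groups match in heavy atoms and differ in their hydrogen-bond acceptors, yet nothing here explains the step.

The change removes chloro and fluoro and adds methoxy in a single step, so the compounds shown do not separate the part each plays. Going by these compounds, how a plain phenyl, a 3-chlorophenyl or a 4-fluorophenyl on the sulfonyl sulfur would read remains open, as does whether the step would hold with the 3-fluorophenyl of compound 2.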